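Capping the hydroxymethyl: from compound 2 to compound 4

The source may hold more compounds than are shown below. What is called first, only, known or untested is meant among the compounds shown, and "the series" means these compounds.

compound 1 `O/N=C(/Nc1cccc(F)c1)c1ccc2occc2c1`: 20000 nM
compound 2 `OCc1cc2cc(/C(=N\O)Nc3cccc(F)c3)ccc2o1`: 2400 nM
compound 3 `OCc1cc2cc(/C(=N\O)Nc3cccc(Cl)c3)ccc2o1`: 5900 nM

In an assay on tissue (HeLa cells) for inhibition of Indoleamine 2,3-dioxygenase 1 (Homo sapiens), read by spectrophotometry (on this read-out lower numbers stand for stronger inhibition and higher numbers for weaker inhibition), compound 2 gives the lowest number of the three measured compounds. Putting hydroxymethyl in place of hydrogen on the aromatic carbon gave an 8.3-fold lower number from compound 1 to compound 2 (0.92 log units; beyond the scatter), and chloro in place of fluoro on the other ring gave a 2.5-fold higher number from compound 2 to compound 3 (0.39 log units; beyond the scatter).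

Compound 4 `COCc1cc2cc(/C(=N\O)Nc3cccc(F)c3)ccc2o1` differs from compound 2 by methyl in place of hydrogen on an oxygen on a saturated carbon. Among the compounds with values here, no measured step touches this oxygen, so only the step of an 8.3-fold lower number from compound 1 to compound 2 (0.92 log units; beyond the scatter) bears on it, and it shows that the hydroxymethyl group as a whole carries the gain. Compound 4 is therefore expected to lose part of that gain, with a step of a 1.9-fold higher number from compound 2 to compound 4 (0.27 log units; within the scatter). Compound 4 is estimated at 4500 nM, between 1500 nM and 14000 nM.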

Compound 4, half-maximal inhibitory concentration: 6100 nM
For compound 4 the middle estimate is 1.4-fold (0.13 log units) below the measured one, within the range that was stated.
By their numbers in this assay, from the lowest: compound 2; then compounds 3 and 4 (each within the scatter of the next); then compound 1.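

Methyl on the oxygen of the hydroxymethyl group gave a 2.5-fold higher number from compound 2 to compound 4 (0.41 log units; beyond the scatter) and so showed that the lowest number in the series depends on that oxygen staying uncapped. Yet methoxymethyl in place of hydrogen on the aromatic carbon still gave a 3.3-fold lower number from compound 1 to compound 4 (0.52 log units; beyond the scatter) and so kept part of the gain without the hydroxy hydrogen.

From the compounds shown here alone, whether an amine, a carboxylic acid or a longer chain at this position would keep that gain remains open. So does whether capping the oxygen has the same effect with chloro in place of fluoro. Nothing available explains the size of either step.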